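The compounds below may be only part of what the source reports. "The series", "measured", "known", "first", "only" and "open" are said of these compounds alone.

Measured compounds:
Compound 1, `CN(C(=O)NC(=O)c1cccc(C(F)(F)F)c1)c1nc(C(F)(F)F)c(C(=O)N/N=C/c2ccccc2C(F)(F)F)s1`, in a functional assay on BCG823 cells (Homo sapiens) for inhibition, read by MTT assay, with a stated time of 72 h (on this read-out lower numbers stand for stronger inhibition and higher numbers for weaker inhibition), gives 7.29 ug/mL.
Compound 2, `CN(C(=O)NC(=O)c1c(F)cccc1F)c1nc(C(F)(F)F)c(C(=O)N/N=C/c2cccc(C(F)(F)F)c2)s1`, in this assay gives 25.9 ug/mL.
Compound 3, `Cc1nc(N(C)C(=O)NC(=O)c2c(F)cccc2F)sc1C(=O)N/N=C/c1ccccc1C(F)(F)F`, in this assay gives 7.88 ug/mL.

Among these three numbers compound 3 stands second highest. Its nearest neighbour is compound 1, whose number is slightly lower, a gap that lies within the scatter of repeated measurements, so the two cannot be told apart. Compound 2 sits furthest away, with a number beyond the scatter higher than that of compound 3.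

Compound 4, `CN(C(=O)NC(=O)c1c(F)cccc1F)c1nc(C(F)(F)F)c(C(=O)N/N=C/c2ccccc2C(F)(F)F)s1`, has not yet been measured. It differs from compound 3 in one place: trifluoromethyl in place of methyl on an aromatic carbon. Among the compounds with values here, no pair of measured compounds shows this same single change, so its effect cannot be read off directly. Compounds 1 and 2 both carry the trifluoromethyl group at this position, yet their numbers lie on both sides of compound 3 and differ in other places as well.

The step from compound 3 to compound 4 is therefore expected to be small, a 1.3-fold higher number from compound 3 to compound 4 (0.10 log units; within the scatter), not clearly beyond the scatter in either direction. Compound 4 is estimated at 10 ug/mL, within a range from 4 ug/mL to 25 ug/mL.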

Compound 4, half-maximal inhibitory concentration: 17 ug/mL
Estimate against measurement, compound 4: 1.7-fold (0.23 log units) below; low and high end bracket the measured number.
By their numbers in this assay, from the lowest: compounds 1 and 3 (each within the scatter of the next); then compounds 4 and 2 (each within the scatter of the next).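

In this assay, within the data shown here, the change from methyl to trifluoromethyl on the aromatic carbon next to the ring nitrogen can now be read on its own for the first time: it gives a 2.2-fold higher number from compound 3 to compound 4 (0.33 log units; beyond the scatter) and so a modest weakening of inhibition, small in size but beyond the scatter, which the earlier compounds, differing in several places at once, could not show. Compound 4 also links this position to the rest of the series: 2-(trifluoromethyl)phenyl in place of 3-(trifluoromethyl)phenyl gives a 1.5-fold lower number from compound 2 to compound 4 (0.18 log units; within the scatter) and stays within the scatter, while 2,6-difluorophenyl in place of 3-(trifluoromethyl)phenyl on the carbonyl carbon gives a 2.3-fold higher number from compound 1 to compound 4 (0.37 log units; beyond the scatter) as another modest step beyond the scatter. Nothing available here accounts for the direction or size of these steps.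

This position is covered by only methyl and trifluoromethyl among the compounds shown, so it remains open how a plain hydrogen, an amine or a longer chain would read there. On these data alone, the methyl to trifluoromethyl step also rests on a single pair, so whether it would hold with other groups elsewhere on the shared core remains unknown.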